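The source may hold more compounds than are shown below. What is called first, only, known or untested is meant among the compounds shown, and "the series" means these compounds.

Compound 1 `COc1ccc(-c2cc3ccccc3c(-c3cccc(N)c3)n2)cc1`: 18800 nM in an ADME assay on MCF-10A cells (Homo sapiens) for cytotoxicity, read by CCK-8 assay and cell counting, with a stated time of 72 h; a lower number here means a stronger inhibitor, a higher number a weaker inhibitor.
Compound 2 `COc1ccc(-c2cc3ccccc3c(-c3ccc(O)cc3)n2)cc1`: in this assay compound 2 gives only a limit, > 50000 nM.
Compound 3 `COc1cc(OC)cc(-c2cc3ccccc3c(-c3cccc(N)c3)n2)c1`: in this assay compound 3 likewise gives only a limit, > 50000 nM.

The step 4-hydroxyphenyl in place of 3-aminophenyl on an aromatic carbon produced an at least 2.6-fold higher number from compound 1 to compound 2 (0.42 log units; beyond the scatter). Compound 4 `COc1cc(OC)cc(-c2cc3ccccc3c(-c3ccc(O)cc3)n2)c1` carries the same kind of change on the core of compound 3, (4-hydroxyphenyl in place of 3-aminophenyl on an aromatic carbon); the two surroundings differ only in that the first is described as meta to a 4-methoxyphenyl group (8 heavy atoms) and the second as meta to a large group. How the cores of compound 1 and compound 3 differ is not broken down here.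

Compound 4 is expected to stay at the limit, the step that the limit leaves unreadable from compound 3 to compound 4 being estimated because of the limit of > 50000 nM in this assay, at which 2 of the 3 values shown sit, and because compound 3 already sits there with > 50000 nM. The estimate for compound 4 is 90000 nM, between 45000 nM and 250000 nM.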

Compound 4, half-maximal inhibitory concentration: 7280 nM
For compound 4 the middle estimate is 12-fold (1.09 log units) above the measured one, and the stated range ends above it.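

In this assay, putting 4-hydroxyphenyl in place of 3-aminophenyl gave an at least 6.8-fold lower number from compound 3 to compound 4 (0.83 log units; beyond the scatter). Set beside the earlier step, the same change does not carry over between these two cores, since its direction reverses: the same change on two cores in this assay, an at least 2.6-fold higher number (0.42 log units; beyond the scatter) from compound 1 to compound 2 and an at least 6.8-fold lower number (0.83 log units; beyond the scatter) from compound 3 to compound 4, at least 18-fold (1.26 log units) apart, beyond the scatter of two such steps. On these data alone, this shows that the result of the change differed between these two pairs, but it does not show which difference between the cores is responsible, and the exact size of each step remains unknown, as compound 2 and compound 3 are given only as limits.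

The compounds shown leave open how the change behaves on any other core. They also leave open what a 4-aminophenyl or 3-hydroxyphenyl group would give on either core.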